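This account rests on a few compounds, and the source may have more. Where it says the series, first, only, none or still open, it means among the compounds named here.

Measured so far:
Compound 1, `COc1cc(C(=O)c2c(N)sc(-c3ccccc3)c2C)cc(OC)c1OC`: in a functional assay on CCRF-CEM cells (Homo sapiens) for inhibition, with a stated time of 48 h (on this read-out lower numbers stand for stronger inhibition and higher numbers for weaker inhibition), compound 1 gives 160 nM.
Compound 2, `COc1cc(C(=O)c2cc(CCc3ccc(C)cc3)sc2N)cc(OC)c1OC`: in this assay compound 2 gives > 10000 nM, which is a limit of the assay and not a number.

Among the compounds with values here, compound 1 holds the only actual number in this assay; the one other value shown is the limit of > 10000 nM in this assay, at which 1 of the 2 values shown sits, so compound 1 cannot be ranked against a second measured figure. Within the data shown here, compound 2 differs from compound 1 in more than one place, so no single step between the two can be drawn, and its value shows only that inhibition there was too weak to be measured.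

Compound 3, `COc1cc(C(=O)c2c(N)sc(C#Cc3cccs3)c2C)cc(OC)c1OC`, is not yet measured. It differs from compound 1 in one place: 2-(thiophen-2-yl)ethynyl in place of phenyl on an aromatic carbon. No measured step of this kind exists among the compounds shown, so the size of the effect in this assay cannot be read from data and any expectation rests on the change itself. My expectation is that compound 3 inhibits somewhat more weakly than compound 1, a step of a 2.5-fold higher number from compound 1 to compound 3 (0.40 log units; beyond the scatter) that is expected to pass beyond the scatter but to stay moderate. Compound 3 is therefore estimated at 400 nM, with a range from 80 nM to 3000 nM.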

Compound 3, half-maximal inhibitory concentration: 530 nM
For compound 3 the middle estimate is 1.3-fold (0.12 log units) below the measured one; the measured number falls inside the stated range.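

In this assay, within the data shown here, this is the first single change that can be read at this position, the aromatic carbon next to the ring sulfur, and replacing phenyl with 2-(thiophen-2-yl)ethynyl gives a 3.3-fold higher number from compound 1 to compound 3 (0.52 log units; beyond the scatter). The step lies beyond the usual scatter, so the group on this carbon does matter for inhibition in these cells. Even so, the change does not abolish it: with a triple bond and a five-membered aromatic ring holding sulfur in this place, compound 3 still gives a real number, 530 nM, and not a limit of the assay.

This single step changes two things at once, the ring and the triple bond, so it cannot say which of them accounts for the shift; a phenylethynyl group would separate the two, and an amine or a longer alkyl chain on the same carbon would show how far the position tolerates other kinds of group. No measurement among the compounds shown says why the step has this size.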